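Amino acid tail in place of piperidine on a shared core

A few compounds are considered here, and "the series" means these few. Any claim that something is new, unique, unknown or untested is made for them only; others in the source may bear on it.

compound 1 `CCCCCCCCCCc1ccc(-c2noc(CC3CNC3)n2)cc1`: 63%
compound 2 `CCCCCCCCCCc1ccc(-c2noc(CC3CCNC3)n2)cc1`: 44%
compound 3 `CCCCCCCCCCc1ccc(-c2noc(C3CCNCC3)n2)cc1`: 66%

In an assay on HeLa cells for inhibition of sphingosine-1-phosphate transporter SPNS2 (Mus musculus), read by LC-MS, tested at 2 uM (on this read-out higher numbers stand for more inhibition at the one concentration tested (going by the name of the read-out) and lower numbers for less inhibition), compound 3 gives 66%, the highest of the three numbers, although compound 1 sits within the scatter of it (a number 3 percentage points higher from compound 1 to compound 3 (within the scatter)) while compound 2 lies beyond it (a number 22 percentage points higher from compound 2 to compound 3 (beyond the scatter)). Compound 4 `CCCCCCCCCCc1ccc(-c2noc(CC[C@@H](N)C(=O)O)n2)cc1` differs from compound 3 by 3-amino-3-carboxypropyl in place of piperidin-4-yl on an aromatic carbon. Among the compounds with values here, no measured step exchanges a ring amine for an open chain carrying an acid; the known steps of a number 19 percentage points lower from compound 1 to compound 2 (beyond the scatter) and a number 22 percentage points higher from compound 2 to compound 3 (beyond the scatter) only show that reshaping the amine-bearing group moves the read-out by modest amounts. Without a direct precedent, a modest fall is expected, a number 16 percentage points lower from compound 3 to compound 4 (beyond the scatter). Compound 4 is therefore estimated at 50%, with a wide range from 20% to 80%.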

Compound 4, a percentage reported as inhibition, at one concentration (the size of the read-out at that concentration, not a potency): 5%
For compound 4 the middle estimate is 45 percentage points above the measured one; the measured number lies below the stated range.
By their numbers in this assay, from the lowest: compound 4; then compound 2; then compounds 1 and 3 (each within the scatter of the next).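

In this assay, the three ring amines differ by modest steps at most, but 3-amino-3-carboxypropyl on this aromatic carbon costs far more, with large falls against every ring (a number 61 percentage points lower from compound 3 to compound 4 (beyond the scatter); a number 58 percentage points lower from compound 1 to compound 4 (beyond the scatter); a number 39 percentage points lower from compound 2 to compound 4 (beyond the scatter)). Even compound 2, the lowest of the ring amines, stands well clear of compound 4, so this position accepts a change of amine-bearing ring far better than this open amino acid chain. Nothing measured here accounts for the fall. What the compounds shown leave open is whether the loss follows the carboxylic acid or the open chain. An open-chain amine without a carboxylic acid, or a piperidine bearing one, would separate the two.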